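Swapping an Aryl Group for Imidazole on the Core

This account rests on a few compounds, and the source may have more. Where it says the series, first, only, none or still open, it means among the compounds named here.

Measured so far:
- Compound 1, `FC(F)(F)c1cccc(-c2nc(NCc3ccc(-c4cccnc4)cc3)c3ccccc3n2)c1`: "not active" (no number reported)
- Compound 2, `FC(F)(F)c1ccc(-c2nc(NCc3ccc(-c4cccnc4)cc3)c3ccccc3n2)cc1`: "not active" (no number reported)
- Compound 3, `Clc1ccccc1-c1nc(NCc2ccc(-c3cccnc3)cc2)c2ccccc2n1`: 2100 nM

All three were tested in an assay on a protein complex for inhibition of ubiquitin carboxyl-terminal hydrolase 1/WD repeat-containing protein 48 (Homo sapiens), read by fluorescence; on this read-out higher numbers stand for weaker inhibition and lower numbers for stronger inhibition. Compound 1 and compound 2 are reported only as not active, without a number. Among the compounds with values here, compound 3 is the single compound with a measured value, 2100 nM, so it is the only point of reference here; nothing can be said about how it ranks against compound 1 or compound 2 beyond the fact that those two gave no number.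

Compound 4, `c1cncc(-c2ccc(CNc3nc(-n4ccnc4)nc4ccccc34)cc2)c1`, is the next compound. It differs from compound 3 by 1H-imidazol-1-yl in place of 2-chlorophenyl on an aromatic carbon. Within the data shown here, no step between two measured compounds covers a change of this kind, so there is no direct guide to its size or direction. Given that two other aryl groups at this position led to no measurable activity, the step of a 2.4-fold higher number from compound 3 to compound 4 (0.38 log units; beyond the scatter) is expected to be a loss, likely beyond the scatter. Compound 4 is therefore estimated at 5000 nM, with a wide range from 1000 nM to 25000 nM.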

Compound 4, half-maximal inhibitory concentration: "not active" (no number reported)
The entry for compound 4 holds no number; the estimate stays without a comparison.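

Within the data shown here, compound 4 is recorded as "not active" (no number reported) and so no step from compound 3 to compound 4 can be read. Nothing measured here offers an explanation for this result. The compounds shown leave open how far 1H-imidazol-1-yl in place of 2-chlorophenyl shifts inhibition.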